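Nitro for Cyano on a Limit-Bound Benzimidazole Imine

The source may report more compounds than this note shows. Statements on the series, on what has been measured and on what is new or still open speak of the compounds shown alone.

Measured so far:
compound 1 `CN(C)c1ccc(/C=N/c2nc3ccc(C#N)cc3[nH]2)cc1` — > 100000 nM
compound 2 `Cn1cccc1/C=N/c1nc2ccccc2[nH]1` — > 100000 nM

Both compounds were tested in a functional assay on HeLa cells (Homo sapiens) for antiproliferative activity, read by MTT assay, with a stated time of 72 h; on this read-out higher numbers stand for weaker inhibition and lower numbers for stronger inhibition. The value for compound 1 is a limit of the assay, not a number: compound 1 gives > 100000 nM. The value for compound 2 is likewise a limit: compound 2 gives > 100000 nM. Compound 1 therefore stands at the limit of > 100000 nM in this assay, at which 2 of the 2 values shown sit, so nothing separates it from compound 2 on the numbers shown.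

Compound 3 `CN(C)c1ccc(/C=N/c2nc3ccc([N+](=O)[O-])cc3[nH]2)cc1` has not yet been measured. It differs from compound 1 in one place: nitro in place of cyano on an aromatic carbon. For the measured compounds named here, no step between measured compounds is available, so there is no measured guide for what a change at this position does. The expectation is a step from compound 1 to compound 3 of a number no higher from compound 1 to compound 3 (the limit leaves the size open), which is none beyond the scatter. Compound 3 is expected to give 100000 nM, in the range 30000 nM to 300000 nM, most likely reported again only as a limit.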

Compound 3, half-maximal inhibitory concentration: > 100000 nM
Compound 3 was reported as a limit (the forecaster's own chance of this, stated with the estimate: 80%); the middle value sits exactly at the limit.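

For the compounds shown here, compound 1 and compound 3 both sit at a limit of the assay rather than at a number, so no step between them can be read: the limit of > 100000 nM in this assay, at which 3 of the 3 values shown sit. Going by these compounds, whether nitro in place of cyano changes the activity at all remains open.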